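The source may report more compounds than this note shows. Statements on the series, on what has been measured and on what is new or still open speak of the compounds shown alone.

Measured compounds:
Compound 1, `CC(C)(N)C(=O)N[C@H](COCc1ccccc1)c1nnnn1Cc1ccc(NS(C)(=O)=O)cc1`: > 5000 nM
Compound 2, `CC(C)(N)C(=O)N[C@H](COCc1ccccc1)c1nnn(Cc2ccccc2)n1`: 4750 nM

Of the compounds shown here, two have been measured in an assay on isolated protein for displacement of a labelled ligand from growth hormone secretagogue receptor type 1 (Homo sapiens), with a stated time of 1 h; a lower number here means a stronger inhibitor, a higher number a weaker inhibitor. Compound 1 reaches only the limit of the assay at > 5000 nM, so no number is known for it. Going by the values given here, compound 2 gives 4750 nM in this assay, the only actual number among the two values shown. The other value, that of compound 1, is a limit, in line with the limit of > 5000 nM in this assay, at which 1 of the 2 values shown sits.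

Compound 3, `CC(C)(N)C(=O)N[C@H](COCc1ccccc1)c1nnn(Cc2ccc(NS(C)(=O)=O)cc2)n1`, has not been measured. It differs from compound 2 in one place: methanesulfonamido in place of hydrogen on an aromatic carbon. Among the compounds with values here, no step between measured compounds is available to guide the expectation, so the size of this step is uncertain. Given that compound 2 sits at 4750 nM, the expected step is a 1.2-fold higher number from compound 2 to compound 3 (0.06 log units; within the scatter), small and within the scatter. Compound 3 is expected to give about 5500 nM, with a range from 2000 nM to 15000 nM, and there is a fair chance the assay reports only a limit.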

Compound 3, inhibition constant: > 5000 nM
Compound 3 gave a limit, no number; the forecaster's own chance of this, stated with the estimate: 50%; the middle value is on the limit's open side.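

Adding methanesulfonamido to the phenyl group of compound 2 gives no measurable gain: compound 3 gives > 5000 nM in this assay, which is a limit and not a number. The step can be read only as a floor, an at least 1.0-fold higher number from compound 2 to compound 3 (0.02 log units; that floor lies within the scatter), so the change may do nothing at all or may do more than this floor shows. What can be said of this position is that 4-(methanesulfonamido)phenyl does not bring the compound below the limit, and the reading is bounded by that limit: the limit of > 5000 nM in this assay, at which 2 of the 3 values shown sit.

On these data alone, how far compound 3 lies past the limit remains open, and so does the true size of the step. Also open, as far as these compounds go, is whether a different group at this place, such as an amine or a carboxylic acid, would give a measurable change.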